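The source may hold more compounds than are shown below. What is called first, only, known or untested is meant among the compounds shown, and "the series" means these compounds.

Among the measured compounds shown here, in a functional assay on HL-60 cells (Homo sapiens) for cytotoxicity, read by luminescence and CellTiter-Glo, with a stated time of 3 days (a lower number here means a stronger inhibitor, a higher number a weaker inhibitor), compound 1 (`O=C(Nc1ccc(C(F)(F)F)cc1)c1cc(Cl)ccc1O`) gives 510 nM as the lower of the two numbers so far. Compound 2 (`N#Cc1ccc(NC(=O)c2cc(F)ccc2O)cc1`) gives 1420 nM and stands highest of the two, beyond the scatter from compound 1. Compound 3 (`N#Cc1ccc(NC(=O)c2cc(Cl)ccc2O)cc1`) keeps the nitrile of compound 2 and changes one place (chloro in place of fluoro on an aromatic carbon): chloro in place of fluoro on an aromatic carbon, para to a hydroxy group. For the measured compounds named here, no measured pair isolates this change: compound 1 and compound 2 differ in trifluoromethyl against nitrile as well as chloro against fluoro. Compound 3 shares its chloro with compound 1, which at 510 nM lies lower, so a modest step toward a lower number in this assay is expected, though it may stay within the scatter. The working estimate is a 1.9-fold lower number from compound 2 to compound 3 (0.28 log units; within the scatter) for this change. Compound 3 is expected at 750 nM (estimated range 320 nM to 1700 nM).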

Compound 3, half-maximal inhibitory concentration: 700 nM
Estimate against measurement, compound 3: 1.1-fold (0.03 log units) above; low and high end bracket the measured number.
By their numbers in this assay, from the lowest: compounds 1 and 3 (each within the scatter of the next); then compound 2.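

In this assay, chloro in place of fluoro on an aromatic carbon, para to a hydroxy group, now stands as a single change with the nitrile held constant: a 2.0-fold lower number from compound 2 to compound 3 (0.31 log units; beyond the scatter) is a modest step at this position. Cyano in place of trifluoromethyl on an aromatic carbon also stands alone with the chloro held constant (a 1.4-fold higher number from compound 1 to compound 3 (0.14 log units; within the scatter)), so the gap between compound 1 and compound 2 separates into two steps, of which only the halogen step lies beyond the scatter. Nothing available bears on the reason for either step. 

From the compounds shown here alone, whether the halogen step holds the same size with trifluoromethyl in place of the nitrile remains open. Also open, going by these compounds, is what bromo, methoxy or an amine would give at this position.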